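A few compounds are considered here, and "the series" means these few. Any claim that something is new, unique, unknown or untested is made for them only; others in the source may bear on it.

Working notes on the thiazolidinedione series, with activity read in a functional assay for agonist activity at Free fatty acid receptor 1 (Homo sapiens), read by FLIPR, in the presence of a further agent that is not named here; a higher number here means that more compound is needed for the effect, a lower number that less compound is needed.

Of the compounds shown here, three have been measured. Compound 1 `Cc1ccc(C)c(Oc2ccc(CC3SC(=O)NC3=O)cc2)c1` gives 238 nM in this assay. Compound 2 `Cc1cc(Oc2ccc(CC3SC(=O)NC3=O)cc2)cc(C)c1C#N` gives 120 nM, a number that sits within the scatter of repeated measurements relative to compound 1, so the two cannot be ordered. Compound 3 `O=C1NC(=O)C(Cc2ccc(Oc3ncc(C(F)(F)F)cc3Cl)c3ccccc23)S1`, built on a different aryl ether and a different aromatic core, gives 23600 nM, a number far beyond the scatter from compound 1 and the only one of the three that stands clearly apart. Among the three numbers, compound 1 has the second highest, nearest to compound 2 and furthest from compound 3.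

Compound 4 `Cc1cccc(Oc2ccc(CC3SC(=O)NC3=O)cc2)c1` has not been measured in this assay. It differs from compound 1 in one place:

hydrogen in place of methyl on an aromatic carbon

Among the compounds with values here, no measured pair in the set shares this change, so no step can be computed for it. Given that compound 2, which also carries methyl groups on that ring, gives 120 nM, the ring substitution here appears to tolerate variation. The loss of one methyl is expected to cost a little, with a step of a 1.8-fold higher number from compound 1 to compound 4 (0.25 log units; within the scatter) from compound 1 to compound 4 expected, roughly at the edge of the scatter. Compound 4 is therefore estimated at 420 nM, with a range of 150 nM to 1200 nM.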

Compound 4, half-maximal effective concentration: 203 nM
Compound 4: the middle estimate sits 2.1-fold (0.32 log units) above what was measured; the range from low to high includes it.
By their numbers in this assay, from the lowest: compounds 2, 4 and 1 (each within the scatter of the next); then compound 3.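

In this assay, hydrogen in place of methyl on an aromatic carbon, ortho to a large group and para to a methyl group, gives a 1.2-fold lower number from compound 1 to compound 4 (0.07 log units; within the scatter), so compound 1 and compound 4 cannot be told apart and this methyl group is not required for activity at the level of this pair. The earlier compounds shown here differ from one another in more than one place and could not isolate any single position, whereas this pair isolates one, although the result applies only to this change on the core of compound 1. No supporting data bear on why the step is this small.

Whether this aromatic carbon accepts anything other than methyl or hydrogen remains open, as a methoxy group, a chlorine atom or an amine at this position appears nowhere among the compounds shown. Also open, on these data alone, is whether the remaining methyl group can be replaced by hydrogen as well, leaving the ring without either methyl group, and whether the same change would give a similar step on the core of compound 3.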